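Chain-shortened chloro analogue of compound 1

This account rests on a few compounds, and the source may have more. Where it says the series, first, only, none or still open, it means among the compounds named here.

Within the data shown here, compound 1 `CCCCCCc1cc2cn(Cc3cn(Cc4ccccc4)nn3)c(=O)nc2o1` gives 68700 nM in a functional assay on HepG2 cells (Homo sapiens) for antiproliferative activity, read by MTT assay, with a stated time of 72 h (on this read-out lower numbers stand for stronger inhibition and higher numbers for weaker inhibition), and is the only compound in the set with a number rather than a limit. Compound 2 `CCCCCCC#Cc1c(CCCCCC)oc2nc(=O)n(Cc3cn(-c4ccc(Cl)cc4)nn3)cc12` reaches only the limit > 100000 nM in this assay. Compound 3 `CCCCCCc1cc2cn(Cc3cn(-c4ccccc4F)nn3)c(=O)nc2o1` likewise stops at the limit > 100000 nM. Among the measured compounds shown here, the single measured step, an at least 1.4-fold higher number from compound 1 to compound 3 (0.16 log units; that floor lies within the scatter), comes from 2-fluorophenyl in place of benzyl on an aromatic nitrogen and rests on (the limit of > 100000 nM in this assay, at which 2 of the 3 values shown sit), so its true size is open. Compound 4 `O=c1nc2oc(CCCCl)cc2cn1Cc1cn(Cc2ccccc2)nn1` differs from compound 1 by chloro in place of propyl on a saturated chain carbon, three bonds along the chain from an aromatic carbon. For the measured compounds named here, no measured pair alters this chain, so no step bears on the change, and no shift beyond the scatter is assumed in this assay. Compound 4 is therefore expected near 70000 nM, between 25000 nM and 250000 nM, a step of a 1.0-fold higher number from compound 1 to compound 4 (0.01 log units; within the scatter).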

Compound 4, half-maximal inhibitory concentration: 27600 nM
The estimate for compound 4 lay 2.5-fold (0.40 log units) above the measured number, and the stated range covers the measured number.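

Chloro in place of propyl on a saturated chain carbon, three bonds along the chain from an aromatic carbon, gives a 2.5-fold lower number from compound 1 to compound 4 (0.40 log units; beyond the scatter) in this assay. Among these compounds, this is the first step printed as beyond the scatter, so the outer part of the hexyl chain does affect the read-out. Only compounds 1 and 4 carry numbers, which makes this the only step with a firm size: the limit of > 100000 nM in this assay, at which 2 of the 4 values shown sit.

The change shortens the chain and adds chloro at once, and the compounds shown do not separate the two. On these data alone, whether a plain propyl chain or an amine at the chain end would move the number further remains open.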